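The source may hold more compounds than are shown below. What is called first, only, known or untested is meant among the compounds shown, and "the series" means these compounds.

Compound 1 `O=C(CCCCC#Cc1ccncc1)c1ncc(-c2ccccn2)o1` and compound 2 `O=C(CCCCC(=O)c1ncc(-c2ccccn2)o1)Nc1ccccc1` share the same core and differ only in how the chain ends. In an assay for inhibition of Fatty-acid amide hydrolase 1 (Rattus norvegicus) (on this read-out higher numbers stand for weaker inhibition and lower numbers for stronger inhibition), compound 1 gives 150 nM. For the measured compounds named here, compound 2 in this assay gives 3100 nM, which is the higher of the two numbers, and the gap between them lies beyond the scatter; as no step is computed for this pair, only the two values themselves can be compared. Compound 3 `COC(=O)CCCCC(=O)c1ncc(-c2ccccn2)o1` has not yet been measured. It differs from compound 2 in one place: methoxy in place of anilino on a carbonyl carbon. The amide hydrogen of compound 2 is thereby gone and an ester end takes its place. Going by the values given here, no measured pair shows this exact change, so the expectation rests on compound 2 alone, whose value of 3100 nM sets the starting point. A modest step downward is expected, within or just beyond the scatter, as the estimated step of a 2.1-fold lower number from compound 2 to compound 3 (0.32 log units; beyond the scatter) states. For compound 3 the value in this assay is expected to be 1500 nM, with a range from 400 nM to 6000 nM.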

Compound 3, inhibition constant: 1800 nM
Beside the measured number, compound 3's estimate is 1.2-fold (0.08 log units) below it, and the stated range covers the measured number.
By their numbers in this assay, from the lowest: compound 1; then compounds 3 and 2 (each within the scatter of the next).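

In this assay, the anilino group on the carbonyl carbon, with its aromatic ring and amide hydrogen, can give way to the much smaller methoxy with no difference that stands out from the scatter, as a 1.7-fold lower number from compound 2 to compound 3 (0.24 log units; within the scatter) shows. By contrast, placing methoxycarbonyl on the saturated chain carbon, four bonds along the chain from a carbonyl carbon, in place of 2-(pyridin-4-yl)ethynyl gives a 12-fold higher number from compound 1 to compound 3 (1.08 log units; beyond the scatter), so the ester end and the anilino amide end both sit well apart from the end carried by compound 1, and the ring of the anilino group alone does not close that gap. Nothing measured here explains why these chain ends differ or match in this way.

Going by these compounds, it remains open whether a free carboxylic acid or a simple primary amide at the end of the chain would stay level with compound 3 or move towards compound 1. A longer or shorter chain carrying the same methyl ester, and a plain phenyl ring in place of the pyridine at the end of the alkyne, are also untested here, so how much of the gap belongs to the alkyne and how much to the pyridine cannot yet be told.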